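Benzothiazole amides on MCF7: removing the chloro

The source may report more compounds than this note shows. Statements on the series, on what has been measured and on what is new or still open speak of the compounds shown alone.

Measured so far:
compound 1 `COc1ccc(-c2cc(C(=O)Nc3nc4ccc(Cl)cc4s3)nc3cc(-c4ccccc4)nn23)cc1` gives 4890 nM
compound 2 `COc1ccc(-c2cc(C(=O)Nc3nc4ccc(Cl)cc4s3)nc3cc(-c4ccccc4)nn23)cc1OC` gives 6910 nM
compound 3 `COc1cc(-c2cc(C(=O)Nc3nc4ccc(Cl)cc4s3)nc3cc(-c4ccccc4)nn23)cc(OC)c1OC` gives 30200 nM

In a functional assay on MCF7 cells (Homo sapiens) for cytotoxicity, read by MTT assay, with a stated time of 48 h (a lower number here means a stronger inhibitor, a higher number a weaker inhibitor), compound 2 holds the second highest of the three numbers. Its gap to compound 1, a 1.4-fold higher number from compound 1 to compound 2 (0.15 log units; within the scatter), lies within the scatter; the step of a 4.4-fold higher number from compound 2 to compound 3 (0.64 log units; beyond the scatter) lies beyond it, as does a 6.2-fold higher number from compound 1 to compound 3 (0.79 log units; beyond the scatter). Compound 4 `COc1ccc(-c2cc(C(=O)Nc3nc4ccccc4s3)nc3cc(-c4ccccc4)nn23)cc1OC` differs from compound 2 by hydrogen in place of chloro on an aromatic carbon. Going by the values given here, none of the measured steps touches this ring; all three concern methoxy groups on the other aryl ring, so no step bears directly on the change. With nothing to point either way, no shift beyond the scatter is expected. Compound 4 is expected to give about 8500 nM, within 3500 nM to 20000 nM. The expected step is a 1.2-fold higher number from compound 2 to compound 4 (0.09 log units; within the scatter).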

Compound 4, half-maximal inhibitory concentration: 14700 nM
Beside the measured number, compound 4's estimate is 1.7-fold (0.24 log units) below it; measured number inside the range.
By their numbers in this assay, from the lowest: compounds 1 and 2 (each within the scatter of the next); then compound 4; then compound 3.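

In this assay, hydrogen in place of chloro on the 6-chloro-1,3-benzothiazol-2-yl group gives a 2.1-fold higher number from compound 2 to compound 4 (0.33 log units; beyond the scatter), so this position, untouched by the methoxy steps, also moves the number. The step is modest, and the weaker number without chloro rests on this single pair. No measurement at hand explains the shift.

On these data alone, whether the step holds alongside the 4-methoxyphenyl of compound 1 or the 3,4,5-trimethoxyphenyl of compound 3 remains open. So does the outcome with fluoro, methyl or an amine on this carbon.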